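A Longer Chain on a Core Stuck at the Assay Limit

A few compounds are considered here, and "the series" means these few. Any claim that something is new, unique, unknown or untested is made for them only; others in the source may bear on it.

Compound 1 `CCCCSC(=S)C1=C(Nc2ccc(Cl)cc2Cl)CC(C)(C)CC1=O`: > 50 ug/mL
Compound 2 `CCCCCCCCCCCSC(=S)C1=C(Nc2ccc(Cl)cc2Cl)CC(C)(C)CC1=O`: > 50 ug/mL
Compound 3 `CCCCSC(=S)C1=C(Nc2ccc(Cl)cc2)CC(C)(C)CC1=O`: > 50 ug/mL

In a functional assay on PBMC cells (Homo sapiens) for inhibition, read by thymidine incorporation, with a stated time of 72 h (a higher number here means a weaker inhibitor, a lower number a stronger inhibitor), compound 1 gives > 50 ug/mL, a limit of the assay and not a number. Compound 2 gives > 50 ug/mL, also a limit. Compound 3 gives > 50 ug/mL, again a limit. All three values sit at the limit of > 50 ug/mL in this assay, at which 3 of the 3 values shown sit, so no order among them can be read.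

Compound 4 `CCCCCCCCCCCSC(=S)C1=C(Nc2ccc(Cl)cc2)CC(C)(C)CC1=O` differs from compound 3 by heptyl in place of hydrogen on a saturated chain carbon, four bonds along the chain from a sulfur. Going by these compounds, the same change was measured once before, as a step that the two limits leave unreadable from compound 1 to compound 2, but both of its ends are limits, so its size is unknown. With no readable step to build on, compound 4 is expected to give 60 ug/mL, within 20 ug/mL to 200 ug/mL, most likely reported as a limit. The step that the limit leaves unreadable from compound 3 to compound 4 is therefore expected to be essentially none.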

Compound 4, half-maximal inhibitory concentration: > 50 ug/mL
Compound 4: a limit, no number (the forecaster's own chance of this, stated with the estimate: 85%); the middle value does not contradict the limit.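

Compound 4 gives > 50 ug/mL as a limit and not a number. Its steps from compound 2 and from compound 3 therefore cannot be read: the limit of > 50 ug/mL in this assay, at which 4 of the 4 values shown sit. The compounds shown leave open how strongly any of the four inhibits, and whether either change alters that at all.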